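From Dodecyl to tert-Butyl on the Shared Core

A few compounds are considered here, and "the series" means these few. Any claim that something is new, unique, unknown or untested is made for them only; others in the source may bear on it.

Compound 1 `Cc1nc2ccccc2nc1Oc1ccc(C(=O)N[C@@H](CC(C)C)C(=O)O)cc1`: 17300 nM
Compound 2 `CCCCCCCCCCCCNc1nc2ccccc2nc1Oc1ccc(C(=O)N[C@@H](C)C(=O)OC)cc1`: 28500 nM
Compound 3 `CCCCCCCCCCCCNc1nc2ccccc2nc1Oc1ccc(C(=O)N[C@H](C(=O)OC)[C@H](C)CC)cc1`: 40300 nM
Compound 4 `CC[C@@H](C)[C@H](NC(=O)c1ccc(Oc2nc3ccccc3nc2NC(C)(C)C)cc1)C(=O)OC`: not yet measured

In a functional assay on HeLa cells (Homo sapiens) for antiproliferative activity, read by MTT assay, with a stated time of 48 h (a lower number here means a stronger inhibitor, a higher number a weaker inhibitor), compound 3 gives 40300 nM, a higher number than that of compound 1 and one within the scatter of compound 2. The change to compound 4 is tert-butyl in place of dodecyl on a nitrogen on an aromatic ring. For the measured compounds named here, the only measured step, a 1.4-fold higher number from compound 2 to compound 3 (0.15 log units; within the scatter), lies at a different place, a saturated chain carbon, and no measured pair varies the group on this nitrogen. No change beyond the scatter is therefore expected in this assay, though this expectation rests on little. The expected step is a 1.2-fold lower number from compound 3 to compound 4 (0.06 log units; within the scatter). For compound 4 the estimated value is 35000 nM, with an expected range from 14000 nM to 90000 nM.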

Compound 4, half-maximal inhibitory concentration: 31900 nM
Beside the measured number, compound 4's estimate is 1.1-fold (0.04 log units) above it; measured number inside the range.
By their numbers in this assay, from the lowest: compounds 1, 2, 4 and 3 (each within the scatter of the next, the first and the last beyond it).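

In this assay, for the compounds shown here, the only measured change on a nitrogen on an aromatic ring gives a 1.3-fold lower number from compound 3 to compound 4 (0.10 log units; within the scatter) when tert-butyl replaces dodecyl. The earlier compounds shown here varied only a saturated chain carbon, whereas this pair shows that the group on this nitrogen can change this much in size and shape with a step that stays within the scatter. Nothing at hand explains this result. Still open, going by these compounds, is whether a cyclohexyl ring or a chain ending in an amine on this nitrogen would also stay within the scatter.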